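The source may hold more compounds than are shown below. What is called first, only, known or untested is meant among the compounds shown, and "the series" means these compounds.

Compound 1 `COc1ccccc1CN1CCC=C(CCC(=O)NO)C1=O`: > 10000 nM
Compound 2 `Cc1cccc(CN2CCC=C(CCC(=O)NO)C2=O)c1`: > 10000 nM

Both results come from a functional assay on PC-3 cells (Homo sapiens) for inhibition, read by sulforhodamine B assay; a lower number here means a stronger inhibitor of growth, a higher number a weaker inhibitor of growth. Compound 2 stands at > 10000 nM, which is a limit of the assay and not a number. Compound 1 reads > 10000 nM, and that is a limit too. The picture so far is therefore (the limit of > 10000 nM in this assay, at which 2 of the 2 values shown sit). Among the measured compounds shown here, neither compound has an exact value, and no measured step is available to show how large a structural change might be.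

Compound 3 `Cc1ccccc1CN1CCC=C(CCC(=O)NO)C1=O` keeps the shared core and has the same atoms as compound 2, joined differently. It carries 2-methylphenyl in place of 3-methylphenyl on a saturated chain carbon bound to an amide-type nitrogen in a ring. In this assay, no step beyond the usual scatter is expected from this swap, and no direction is favoured. This expectation rests on compound 1 and compound 2 sharing (the limit of > 10000 nM in this assay, at which 2 of the 2 values shown sit). Another limit is the most likely report. The estimated change is a step that the limit leaves unreadable from compound 2 to compound 3. For compound 3 the expected value is 15000 nM, with an estimated range of 6000 nM to 40000 nM.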

Compound 3, concentration for 50% growth inhibition: > 10000 nM
Compound 3: a limit, no number; the forecaster's own chance of this, stated with the estimate: 80%; the middle value is on the limit's open side.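

In this assay compound 3 gives > 10000 nM, which is a limit of the assay and not a number. Among the compounds shown here, no step to compound 3 from compound 1 or compound 2 can be read, and all three compounds share one result: the limit of > 10000 nM in this assay, at which 3 of the 3 values shown sit. The compounds shown leave open how far beyond this limit each true value lies, and whether swapping 3-methylphenyl for 2-methylphenyl, or methoxy for methyl, changes growth inhibition at all.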